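This account rests on a few compounds, and the source may have more. Where it says the series, first, only, none or still open, it means among the compounds named here.

Compound 1, `COc1cc(CNC(=S)NCC(COC(=O)C(C)(C)C)Cc2ccc(C(C)(C)C)cc2)cc(Cl)c1O`, is one of three thiourea analogues sharing a common core and differing only in the aryl group at one end. In an assay on CHO cells for displacement of a labelled ligand from transient receptor potential cation channel subfamily V member 1 (Rattus norvegicus) (a lower number here means a stronger inhibitor, a higher number a weaker inhibitor), compound 1 gives 21.3 nM; compound 2, `COc1cc(CNC(=S)NCC(COC(=O)C(C)(C)C)Cc2ccc(C(C)(C)C)cc2)c(Br)cc1O`, gives 12.8 nM; and compound 3, `COc1cc(CNC(=S)NCC(COC(=O)C(C)(C)C)Cc2ccc(C(C)(C)C)cc2)c(I)cc1O`, gives 13.3 nM. Compound 1 has the highest of the three numbers, but the three lie close together: the step of a 1.7-fold lower number from compound 1 to compound 2 (0.22 log units; within the scatter) and the step of a 1.6-fold lower number from compound 1 to compound 3 (0.20 log units; within the scatter) are both within the scatter, as is a 1.0-fold higher number from compound 2 to compound 3 (0.02 log units; within the scatter). The three measured compounds therefore behave alike in this assay.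

Compound 4, `COc1cc(CNC(=S)NCC(COC(=O)C(C)(C)C)Cc2ccc(C)c(C)c2)cc(Cl)c1O`, is a different kind of variation. Its change from compound 1 is 3,4-dimethylphenyl in place of 4-(tert-butyl)phenyl on a saturated chain carbon, three bonds along the chain from an amide-type nitrogen and an oxygen next to a carbonyl group, on the other side of the molecule from every change studied so far. Going by the values given here, none of the measured steps touches this chain-borne aryl group, so none of them bears directly on the new step; they show only that the core tolerates small changes elsewhere without moving the number beyond the scatter. Among the compounds with values here, with no measured step to anchor it, the expected step of a 2.1-fold higher number from compound 1 to compound 4 (0.32 log units; beyond the scatter) is uncertain, and compound 4 is expected to give about 45 nM, within a range from 12 nM to 180 nM.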

Compound 4, inhibition constant: 30.9 nM
The estimate for compound 4 lay 1.5-fold (0.16 log units) above the measured number, and the stated range covers the measured number.
By their numbers in this assay, from the lowest: compounds 2, 3, 1 and 4 (each within the scatter of the next, the first and the last beyond it).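

In this assay, going by these compounds alone, the exchange of 4-(tert-butyl)phenyl for 3,4-dimethylphenyl gives a 1.5-fold higher number from compound 1 to compound 4 (0.16 log units; within the scatter), the first measured step at this aryl group on a saturated chain carbon, three bonds along the chain from an amide-type nitrogen and an oxygen next to a carbonyl group. Within the data shown here, the position therefore accepts this particular exchange, from a group of 10 heavy atoms to one of 8, without the number moving beyond the scatter, even though the single tert-butyl group gives way to two methyl groups. The earlier compounds varied only the other aryl group, so this step extends the finding of no change beyond the scatter to a second place in the molecule, while no information is available to explain the result.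

On these data alone, both groups at this position are phenyl rings carrying only carbon substituents, so it remains open whether a carboxylic acid, an amine or a longer alkyl chain on that ring would be accepted in the same way. As far as these compounds go, it also remains open whether 3,4-dimethylphenyl would give a similar step when combined with the bromo and iodo aryl groups of compound 2 and compound 3.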